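Replacing a ring amine with a hydroxypropyl pyrrolidine chain

This account rests on a few compounds, and the source may have more. Where it says the series, first, only, none or still open, it means among the compounds named here.

Of the compounds shown here, three sharing a decyl-phenyl-oxadiazole core have been tested in an assay on HeLa cells for inhibition of sphingosine-1-phosphate transporter SPNS2 (Mus musculus), read by LC-MS, tested at 2 uM; a lower number here means less inhibition, a higher number more inhibition at the concentration tested (going by the name of the read-out). Compound 1 `CCCCCCCCCCc1ccc(-c2noc(C3CCNC3)n2)cc1` gives 26%. Compound 2 `CCCCCCCCCCc1ccc(-c2noc([C@@H]3CCCN3)n2)cc1` gives 21%, and compound 3 `CCCCCCCCCCc1ccc(-c2noc([C@@H](N)CCCCN)n2)cc1` gives 43%. Compound 1 therefore stands second highest of the three: its nearest neighbour is compound 2, with a number 5 percentage points lower from compound 1 to compound 2 (within the scatter), while compound 3 sits furthest away, with a number 17 percentage points higher from compound 1 to compound 3 (beyond the scatter). Compound 2 and compound 3 are also separated by a clear step, a number 22 percentage points higher from compound 2 to compound 3 (beyond the scatter).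

The unmeasured compound 4 `CCCCCCCCCCc1ccc(-c2noc(CC(O)CN3CCCC3)n2)cc1` differs from compound 1 in one place: 2-hydroxy-3-(pyrrolidin-1-yl)propyl in place of pyrrolidin-3-yl on an aromatic carbon. The steps from compound 1 and compound 2 to compound 3 show that exchanging the ring amine for an open chain carrying two nitrogens lifted the read-out by a modest amount, whereas moving the amine within the five-membered ring, as from compound 1 to compound 2, changed nothing beyond the scatter. Compound 4 keeps a five-membered ring but attaches it through a chain with a hydroxyl, a change not directly covered by any measured step, so only a small shift is expected, and its direction is uncertain. For compound 4 in this assay the expected step is a number 4 percentage points higher from compound 1 to compound 4 (within the scatter), giving an estimated value of 30%, within a range from 10% to 55%.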

Compound 4, a percentage reported as inhibition, at one concentration (the size of the read-out at that concentration, not a potency): 21%
Beside the measured number, compound 4's estimate is 9 percentage points above it; the measured number falls inside the stated range.
By their numbers in this assay, from the lowest: compounds 2, 4 and 1 (each within the scatter of the next); then compound 3.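

In this assay, putting 2-hydroxy-3-(pyrrolidin-1-yl)propyl at this position, on the aromatic carbon of the core, gives a number 5 percentage points lower from compound 1 to compound 4 (within the scatter) and no change at the digits printed from compound 2 to compound 4 (within the scatter), so this longer group with its added oxygen leaves the read-out level with that of the two compounds carrying a pyrrolidine joined directly to the core. The gain seen with 1,5-diaminopentyl does not carry over to this new chain, as the comparison with the diamine shows a number 22 percentage points lower from compound 3 to compound 4 (beyond the scatter), which means that adding heavy atoms here is not enough on its own to raise the number in this small set. No measured information explains why these groups behave as they do.

On these data alone, it remains open whether the higher number of compound 3 needs both of its amines, a question that a 5-aminopentyl group carrying a single amine at the same position could address. As far as these compounds go, it is equally open whether the hydroxyl of compound 4 matters at all, which a plain 3-(pyrrolidin-1-yl)propyl chain would test, and how a carboxylic acid at this position would read out.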